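The source may hold more compounds than are shown below. What is called first, only, known or untested is meant among the compounds shown, and "the series" means these compounds.

Working notes on the series.

Compound 1 `CNC(=O)c1cc(C(=O)NCCC2CCOCC2)cn(Cc2ccccc2)c1=O` and compound 2 `CNC(=O)c1cc(C(=O)NC2CC2)cn([C@H](C)c2ccccc2)c1=O` share one core and differ in the group on the aromatic nitrogen and in the amide on the other side. In a physicochemical assay for lipophilicity, at pH 7.4 (a lower number here means a more polar compound, a higher number a more lipophilic compound), compound 1 gives 3.6. In this assay compound 2 gives 3.4. Within the data shown here, of the two numbers so far, the one for compound 2 is the lower, but the value of compound 1 lies within the scatter of it, so the two compounds cannot be ordered on this assay.

Compound 3 `CNC(=O)c1cc(C(=O)NC2CC2)cn(Cc2ccccc2F)c1=O` is not yet measured. It differs from compound 2 in one place: 2-fluorobenzyl in place of 1-phenylethyl on an aromatic nitrogen. Among the measured compounds shown here, no measured pair carries this same change, so its effect on this assay is open. The groups that leave and enter have the same count of heavy atoms, one aromatic ring each, and no donors or acceptors, so the expected step from compound 2 to compound 3 is a number 0.10 log units lower from compound 2 to compound 3 (within the scatter), a step that is expected to stay within the scatter. Compound 3 is estimated to give 3.3, with a range from 2.9 to 3.7.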

Compound 3, distribution coefficient: 3
Compound 3: middle estimate off by 0.30 log units, on the high side; the measured number falls inside the stated range.
By their numbers in this assay, from the lowest: compound 3; then compounds 2 and 1 (each within the scatter of the next).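

Working notes, continued.

Among these compounds, with the cyclopropylcarbamoyl group and the methylcarbamoyl group held in place, the group on the aromatic nitrogen is the only difference in this pair, and in this assay the step is a number 0.40 log units lower from compound 2 to compound 3 (beyond the scatter), a modest one. Among the compounds shown here, compounds 1 and 2 differ in two places and could not be ordered, so this is the first sign that a change at this position alone can move the read-out beyond the scatter, even though 1-phenylethyl and 2-fluorobenzyl match in heavy atoms, aromatic rings, donors, acceptors and net charge. Nothing available bears on why this step occurs.

The change from 1-phenylethyl to 2-fluorobenzyl removes the defined stereocentre and brings in fluorine at once, and the compounds shown do not separate these two differences. Going by these compounds, it also remains open whether a step of this size would recur with another amide in place of the cyclopropylcarbamoyl group, or how a longer chain such as 3-phenylpropyl, an amine or a carboxylic acid on the aromatic nitrogen would read in this assay.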